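Swapping Butyl for Phenyl: Compound 3 Expected Inactive

The compounds below may be only part of what the source reports. "The series", "measured", "known", "first", "only" and "open" are said of these compounds alone.

Two compounds share a methoxycarbonyl group on a five-membered aromatic ring with three nitrogen atoms. Compound 1 `COC(=O)c1nc(C)n(-c2ccccc2C(F)(F)F)n1` carries a phenyl bearing a trifluoromethyl group. In a functional assay on NPC-TW01 cells (Homo sapiens) for inhibition, read by MTT assay, with a stated time of 72 h (a higher number here means a weaker inhibitor of growth, a lower number a stronger inhibitor of growth), compound 1 gives only a limit of the assay, > 100000 nM. Compound 2 `CCCCc1nc(C(=O)OC)nn1-c1ccc(F)cc1` carries a butyl group and a fluorine-bearing phenyl. In this assay compound 2 likewise reaches only a limit, > 100000 nM. The whole record so far amounts to the limit of > 100000 nM in this assay, at which 2 of the 2 values shown sit, so neither compound shows measurable growth inhibition and no order between them can be drawn. Compound 3 `COC(=O)c1nc(-c2ccccc2)n(-c2ccc(F)cc2)n1` is the next step: phenyl in place of butyl on an aromatic carbon. Among the measured compounds shown here, no measured step of this kind exists to guide the guess. The step expected here, a number no higher from compound 2 to compound 3 (the limit leaves the size open), stays within the scatter. Compound 3 is therefore estimated at 100000 nM, expected somewhere between 30000 nM and 300000 nM, most likely again only as a limit.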

Compound 3, concentration for 50% growth inhibition: 15600 nM
For compound 3 the middle estimate is 6.4-fold (0.81 log units) above the measured one; the whole stated range lies above it.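

The group on this aromatic carbon, between two ring nitrogen atoms, can decide whether any growth inhibition is seen at all: in this assay, phenyl in place of butyl gives an at least 6.4-fold lower number from compound 2 to compound 3 (0.80 log units; beyond the scatter). Compound 3 is thus the only compound shown with a measured number rather than a limit, so this position responds to the change even though the rest of the molecule stays the same. The true size of the step remains unknown because compound 2 gives only a limit: the limit of > 100000 nM in this assay, at which 2 of the 3 values shown sit.

The compounds shown leave open whether the gain comes from the aromatic ring itself or simply from a larger group, which a cyclohexyl ring or a longer chain at this carbon could help to separate. From the compounds shown here alone, it is also open whether compound 3 would keep its activity with a carboxylic acid in place of the methoxycarbonyl group.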